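Quinoline amides: pyrrolidine substituent swap, phenyl to acylamino

This account rests on a few compounds, and the source may have more. Where it says the series, first, only, none or still open, it means among the compounds named here.

Measured so far:
compound 1 `CCCN(CCC)c1ccc2cc(NC(=O)CCc3ccc(C(F)(F)F)cc3)ccc2n1`, 490 nM in an assay on isolated protein for displacement of a labelled ligand from melanin-concentrating hormone receptor 1 (Homo sapiens); a lower number here means a stronger inhibitor, a higher number a weaker inhibitor
compound 2 `O=C(CCc1ccc(C(F)(F)F)cc1)Nc1ccc2nc(N3CCC(c4ccccc4)C3)ccc2c1`, 25 nM in this assay

Going by the values given here, compound 2 holds the lowest number of the two; the single step to it, a 20-fold lower number from compound 1 to compound 2 (1.29 log units; beyond the scatter), is large. Compound 3 `CC(C)C(=O)NC1CCN(c2ccc3cc(NC(=O)CCc4ccc(C(F)(F)F)cc4)ccc3n2)C1` differs from compound 2 by (isopropylcarbonyl)amino in place of phenyl on a saturated ring carbon. Among the compounds with values here, no measured step touches this position: the one known step concerns the amino group on the aromatic carbon, not the substituent on the saturated ring. The expectation for compound 3 in this assay therefore rests on compound 2 alone and is a moderate loss, a 4.0-fold higher number from compound 2 to compound 3 (0.60 log units; beyond the scatter). Compound 3 is estimated at 100 nM, within 20 nM to 500 nM.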

Compound 3, half-maximal inhibitory concentration: 1 nM
Compound 3: the middle estimate sits 100-fold (2.00 log units) above what was measured; the whole stated range lies above it.
By their numbers in this assay, from the lowest: compound 3; then compound 2; then compound 1.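

Going by these compounds alone, on a saturated ring carbon of the five-membered non-aromatic ring, phenyl is not needed in this assay: (isopropylcarbonyl)amino, which has no ring, gives a 25-fold lower number from compound 2 to compound 3 (1.40 log units; beyond the scatter) and is the lowest of the series so far. Measured against dipropylamino on the aromatic carbon, 3-((isopropylcarbonyl)amino)pyrrolidin-1-yl gives a 490-fold lower number from compound 1 to compound 3 (2.69 log units; beyond the scatter) on the shared core. No measurement on hand accounts for this gain. Open, as far as these compounds go, is which part of the new group carries the gain: a plain amine on that ring carbon, or a longer acyl chain, would separate the amide hydrogen from the isopropyl end.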